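Working notes: fluorophenyl sulfonamides in the cytotoxicity assay

This account rests on a few compounds, and the source may have more. Where it says the series, first, only, none or still open, it means among the compounds named here.

The series is followed in an ADME assay on HEK293 cells (Homo sapiens) for cytotoxicity, read by resazurin assay, with a stated time of 48 h; a higher number here means that more compound is tolerated, a lower number that less compound is tolerated. Compound 1 `O=S(=O)(Nc1ccc(-c2nc3ccccc3o2)cc1)c1cccc(F)c1` gives > 100000 nM in this assay, which is a limit of the assay and not a number. In this assay compound 2 `Cc1ccc(S(=O)(=O)Nc2ccc3oc(-c4ccccc4)nc3c2)cc1` gives 75000 nM and compound 3 `COc1ccc(Cl)cc1S(=O)(=O)Nc1ccc2oc(-c3ccccc3)nc2c1` gives 74000 nM. Within the data shown here, the one step between measured compounds that differ in one place is a 1.0-fold lower number from compound 2 to compound 3 (0.01 log units; within the scatter), a change on the sulfonyl sulfur that leaves the read-out within the scatter.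

Compound 4 `O=S(=O)(Nc1ccc(-c2nc3ccccc3o2)cc1)c1ccc(F)cc1` has not yet been measured. It differs from compound 1 as follows: 4-fluorophenyl in place of 3-fluorophenyl on a sulfonyl sulfur. Among the measured compounds shown here, the only measured step that bears on a change at the sulfonyl sulfur is a 1.0-fold lower number from compound 2 to compound 3 (0.01 log units; within the scatter), which was flat; that step exchanged 4-methylphenyl for 5-chloro-2-methoxyphenyl, whereas the change to compound 4 exchanges 3-fluorophenyl for 4-fluorophenyl. No step beyond the scatter is therefore expected in this assay. Compound 1 stands at the limit of > 100000 nM in this assay, at which 1 of the 3 values shown sits. Compound 4 is expected to stand there as well, and its estimate is 100000 nM with a range from 50000 nM to 200000 nM. This corresponds to an expected step of a number no higher from compound 1 to compound 4 (the limit leaves the size open).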

Compound 4, half-maximal cytotoxic concentration: > 100000 nM
Compound 4 was reported as a limit (the forecaster's own chance of this, stated with the estimate: 65%); the middle value sits exactly at the limit.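

Among these compounds, compound 1 and compound 4 are both reported only as limits in this assay, so no step between them can be read. The compounds shown leave open whether 4-fluorophenyl and 3-fluorophenyl on a sulfonyl sulfur differ at all in this assay.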